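The source may report more compounds than this note shows. Statements on the series, on what has been measured and on what is new or still open speak of the compounds shown alone.

In a physicochemical assay for solubility, read by nephelometry, measured as kinetic solubility, at pH 2.0 (on this read-out higher numbers stand for higher solubility and lower numbers for lower solubility), compound 3 (`CC(C)(C)c1cc(C(=O)Nc2ccccc2)n(Cc2ccccc2)n1`) gives 1.6 ug/mL and holds the lowest of the numbers in hand. The nearest number belongs to compound 1 (`CC(=O)NCc1csc(NC(=O)c2cc(C(C)(C)C)nn2Cc2ccccc2)n1`), which gives 12.5 ug/mL and stands higher. Compound 2 (`CN(C)Cc1csc(NC(=O)c2cc(C(C)(C)C)nn2Cc2ccccc2)n1`) reports only a limit, > 100 ug/mL in this read-out.

Compound 4 (`CNCc1csc(NC(=O)c2cc(C(C)(C)C)nn2Cc2ccccc2)n1`) is not yet measured. The change from compound 3 (4-((methylamino)methyl)-1,3-thiazol-2-yl in place of phenyl on an amide-type nitrogen) puts 4-((methylamino)methyl)-1,3-thiazol-2-yl in place of phenyl on an amide-type nitrogen.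

Within the data shown here, two measured steps bear on this change. The closer one sits at the same place: phenyl in place of 4-((dimethylamino)methyl)-1,3-thiazol-2-yl gave a large step (an at least 62-fold lower number from compound 2 to compound 3 (1.79 log units; beyond the scatter)), and read in reverse it points upward. The other shows that the end of the chain also counts: dimethylamino in place of acetamido gave an at least modest step (an at least 8.0-fold higher number from compound 1 to compound 2 (0.90 log units; beyond the scatter)). Both sizes are open-ended because of the limit of > 100 ug/mL in this assay, at which 1 of the 3 values shown sits, and give a floor rather than a measure.

A large upward move beyond the scatter is therefore expected (a 56-fold higher number from compound 3 to compound 4 (1.75 log units; beyond the scatter)). For compound 4 the estimated value is 90 ug/mL within a range from 30 ug/mL to 200 ug/mL. A limit in place of a number is also expected to be quite possible for compound 4.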

Compound 4, solubility: 25 ug/mL
The estimate for compound 4 lay 3.6-fold (0.56 log units) above the measured number, and the stated range ends above it.
By their numbers in this assay, from the lowest: compound 3; then compounds 1 and 4 (each within the scatter of the next). At a limit, above all of these: compound 2.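

In this assay, the change on the amide-type nitrogen brings a large gain even without the dimethylamino end: 4-((methylamino)methyl)-1,3-thiazol-2-yl in place of phenyl gives a 16-fold higher number from compound 3 to compound 4 (1.19 log units; beyond the scatter). Among these compounds, the amine end proves more sensitive than the earlier compounds could show, as hydrogen in place of methyl on the amine nitrogen gives an at least 4.0-fold lower number from compound 2 to compound 4 (0.60 log units; beyond the scatter), and the size of this step is only a floor: the limit of > 100 ug/mL in this assay, at which 1 of the 4 values shown sits. Methyl in place of acetyl on the amine nitrogen gives a 2.0-fold higher number from compound 1 to compound 4 (0.30 log units; within the scatter), so the methylamino and acetamido ends are not separated in this assay, and of the three chain ends only the dimethylamino end of compound 2 stands apart.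

As far as these compounds go, whether a primary amine, a morpholine or a carboxylic acid on the same chain carbon would track the methylamino or the dimethylamino end remains open. Also open, from the compounds shown here alone, is how the gain divides between the 1,3-thiazol-2-yl ring and the amine, a question that an unsubstituted 1,3-thiazol-2-yl or a phenyl bearing a dimethylaminomethyl group on the amide-type nitrogen would address.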